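The compounds below may be only part of what the source reports. "The series", "measured", "known", "first", "only" and "open" are said of these compounds alone.

Compound 1, `CCCC/C=C\c1cn([C@H]2C[C@H](O)[C@@H](CO)O2)c(=O)[nH]c1=O`, gives 361 ug/mL in a functional assay on L1210 cells (Mus musculus) (a lower number here means a stronger inhibitor, a higher number a weaker inhibitor), the highest of the two numbers seen here, with compound 3 nearest. Compound 3, `CCCCCC#Cc1cn([C@H]2C[C@H](O)[C@@H](CO)O2)c(=O)[nH]c1=O`, gives 219 ug/mL, and the step of a 1.6-fold lower number from compound 1 to compound 3 (0.22 log units; within the scatter) stays within the scatter. Compound 2, `CCC#Cc1cn([C@H]2C[C@H](O)[C@@H](CO)O2)c(=O)[nH]c1=O`, reaches only a limit, > 1000 ug/mL, so its number is not known; (the limit of > 1000 ug/mL in this assay, at which 1 of the 3 values shown sits). The step of an at least 2.7-fold higher number from compound 1 to compound 2 (0.44 log units; beyond the scatter) is therefore at least modest, and the step of an at least 4.5-fold lower number from compound 2 to compound 3 (0.65 log units; beyond the scatter) shows that the shorter chain is where the weakness lies.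

Compound 4, `COCC#Cc1cn([C@H]2C[C@H](O)[C@@H](CO)O2)c(=O)[nH]c1=O`, changes compound 1 in one place: 3-methoxyprop-1-yn-1-yl in place of hex-1-en-1-yl on an aromatic carbon. For the measured compounds named here, the steps that bear on it are those to compound 2 and compound 3, both of which vary the chain on the same aromatic carbon. The 3-methoxyprop-1-yn-1-yl group is short, closer to the but-1-yn-1-yl of compound 2 than to the hept-1-yn-1-yl of compound 3, so the weakening seen in an at least 2.7-fold higher number from compound 1 to compound 2 (0.44 log units; beyond the scatter) is the better guide, and a step of at least modest size toward a higher number is expected in this assay. Compound 4 is thus expected to give 900 ug/mL, between 350 ug/mL and 2500 ug/mL, which means an expected step of a 2.5-fold higher number from compound 1 to compound 4 (0.40 log units; beyond the scatter); a limit rather than a number is a real possibility.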

Compound 4, concentration for 50% inhibition: 254 ug/mL
Beside the measured number, compound 4's estimate is 3.5-fold (0.55 log units) above it; the measured number lies below the stated range.
By their numbers in this assay, from the lowest: compounds 3, 4 and 1 (each within the scatter of the next). At a limit, above all of these: compound 2.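

In this assay, a short chain on this aromatic carbon does not by itself go with a weak compound: the 3-methoxyprop-1-yn-1-yl group stands level with hex-1-en-1-yl, a 1.4-fold lower number from compound 1 to compound 4 (0.15 log units; within the scatter), and with hept-1-yn-1-yl, a 1.2-fold higher number from compound 3 to compound 4 (0.06 log units; within the scatter). The contrast lies instead in methoxy in place of methyl on the saturated chain carbon bound to a triple-bonded carbon, an at least 3.9-fold lower number from compound 2 to compound 4 (0.59 log units; beyond the scatter), which makes compound 4 the compound that goes against the earlier link between a short chain and weakness. Compound 2 remains a limit of the assay and not a number, so the size of that step stays open-ended: the limit of > 1000 ug/mL in this assay, at which 1 of the 4 values shown sits.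

The compounds shown leave open whether the difference from compound 2 depends on the oxygen of the methoxy group, and a hydroxyl or an amine in its place would bear on that. They also leave open whether any group on this carbon, such as a halogen or a phenyl, would give a step toward a lower number beyond the scatter from compounds 1, 3 and 4.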